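Swapping 1-phenylethyl for 4-bromobenzyl on the amine

The source may report more compounds than this note shows. Statements on the series, on what has been measured and on what is new or still open speak of the compounds shown alone.

Compound 1 `COc1ccc(CCCNCc2c(OC)cc(Oc3ccc(Nc4ccccc4)cc3)cc2OC)cc1`: 3230 nM
Compound 2 `COc1cc(Oc2cccc(Nc3ccccc3)c2)cc(OC)c1CN[C@H](C)c1ccccc1`: > 20000 nM
Compound 3 `COc1ccc([C@@H](C)NCc2c(OC)cc(Oc3cccc(Nc4ccccc4)c3)c(OC)c2OC)cc1`: 2440 nM

Three compounds share a diaryl-ether core carrying an aminomethyl arm and have been tested in a functional assay on HCT-116 cells (Homo sapiens) for inhibition, read by MTT assay, with a stated time of 72 h; a higher number here means a weaker inhibitor, a lower number a stronger inhibitor. Compound 1 gives 3230 nM and compound 3 gives 2440 nM; these two values lie within the usual scatter of each other. For compound 2 the result is only a limit, > 20000 nM, and it is the one of the three that sits at the limit of > 20000 nM in this assay, at which 1 of the 3 values shown sits. No two of the measured compounds differ in a single place, so no measured step can be read off.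

Compound 4 `COc1cc(Oc2cccc(Nc3ccccc3)c2)cc(OC)c1CNCc1ccc(Br)cc1` has not yet been tested. Against compound 2 the change is 4-bromobenzyl in place of 1-phenylethyl on an amine nitrogen. Since compound 2 stands only at a limit, the size of the expected step is uncertain; the author expects compound 4 to come back with a number rather than a limit, placing the estimated step from compound 2 to compound 4 at an at least 2.5-fold lower number from compound 2 to compound 4 (0.39 log units; beyond the scatter). The estimate for compound 4 in this assay is 8000 nM, with a range from 2500 nM to 25000 nM.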

Compound 4, half-maximal inhibitory concentration: 6230 nM
Compound 4: middle estimate off by 1.3-fold (0.11 log units), on the high side; the range from low to high includes it.
By their numbers in this assay, from the lowest: compounds 3, 1 and 4 (each within the scatter of the next, the first and the last beyond it). At a limit, above all of these: compound 2.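

In this assay, among these compounds, putting 4-bromobenzyl in place of 1-phenylethyl on the amine nitrogen gives the first step that can be read: an at least 3.2-fold lower number from compound 2 to compound 4 (0.50 log units; beyond the scatter). This shows that the group on this nitrogen matters on the shared core, since a change here alone is enough to bring a compound from a limit to a measured number. The size of the step remains a bound only, because the value of compound 2 is a limit: the limit of > 20000 nM in this assay, at which 1 of the 4 values shown sits.

The change removes a defined stereocentre and brings in a bromine together, so this pair cannot separate the two. As far as these compounds go, whether an unsubstituted benzyl or a 4-chlorobenzyl on the same nitrogen would behave like the 4-bromobenzyl group remains open.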